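Indole ring substituents on the diterpenoid ester series

The compounds below may be only part of what the source reports. "The series", "measured", "known", "first", "only" and "open" are said of these compounds alone.

Measured compounds:
compound 1 `COC(=O)[C@@]1(C)CCC=C2[C@@H]1CC[C@@H](C)[C@]2(C)Cc1c[nH]c2ccccc12` — 4200 nM
compound 2 `COC(=O)[C@@]1(C)CCC=C2[C@@H]1CC[C@@H](C)[C@]2(C)Cc1c[nH]c2ccc(Br)cc12` — 16000 nM
compound 3 `COC(=O)[C@@]1(C)CCC=C2[C@@H]1CC[C@@H](C)[C@]2(C)Cc1c[nH]c2ccc(C(F)(F)F)cc12` — 15000 nM

All three numbers come from a functional assay on T47D cells (Homo sapiens) for inhibition, read by sulforhodamine B assay, with a stated time of 48 h; a lower number here means a stronger inhibitor of growth, a higher number a weaker inhibitor of growth. Compound 1 has the lowest number of the three; its nearest neighbour is compound 3, and in this assay the step is a 3.6-fold higher number from compound 1 to compound 3 (0.55 log units; beyond the scatter). The step to compound 2 is a 3.8-fold higher number from compound 1 to compound 2 (0.58 log units; beyond the scatter). Between compound 2 and compound 3 the step is a 1.1-fold lower number from compound 2 to compound 3 (0.03 log units; within the scatter), so these two cannot be told apart.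

Compound 4 `COC(=O)[C@@]1(C)CCC=C2[C@@H]1CC[C@@H](C)[C@]2(C)Cc1c[nH]c2c(C)cccc12` has not yet been measured. It differs from compound 1 as follows: methyl in place of hydrogen on an aromatic carbon. Going by the values given here, the only steps that bear on this are the two substitutions of hydrogen on an aromatic carbon of the same ring, from compound 1 to compound 2 and from compound 1 to compound 3, both modest increases in the number. Compound 4 places a methyl ortho to a fused ring and meta to a fused ring, a position not sampled in compounds 2 and 3, and methyl has not been tried on this ring at all, so the direction is uncertain. On balance a modest rise in the number is expected, smaller than the two measured steps, with room for no change within the scatter.

Compound 4 is therefore estimated at 7000 nM in this assay, in a range from 3000 nM to 17000 nM, which corresponds to an expected step of a 1.7-fold higher number from compound 1 to compound 4 (0.22 log units; within the scatter).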

Compound 4, concentration for 50% growth inhibition: 18000 nM
Compound 4: the middle estimate sits 2.6-fold (0.41 log units) below what was measured; the whole stated range lies below it.
By their numbers in this assay, from the lowest: compound 1; then compounds 3, 2 and 4 (each within the scatter of the next).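

In this assay, the methyl at this position, ortho to a fused ring and meta to a fused ring, gives a 4.3-fold higher number from compound 1 to compound 4 (0.63 log units; beyond the scatter) and is the first change shown at this carbon. A single added carbon here is therefore enough to move the number beyond the scatter, so the loss seen with bromo and trifluoromethyl elsewhere on the ring is not confined to those two groups or to their position. Among the compounds shown, all three substituted indoles now carry a higher number than unsubstituted compound 1, with none going against this, and no measurement bears on why the methyl has this effect.

Since methyl and the two earlier groups sit at different carbons, the compounds shown do not separate the effect of the group from that of its position, which would take methyl at the carbon bearing bromo, or bromo at the carbon bearing methyl. From the compounds shown here alone, it also remains open whether any group at this carbon can match or lower the number of compound 1, for example fluoro, methoxy, an amine or a carboxylic acid.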